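Removing the bromo group from compound 1

The source may hold more compounds than are shown below. What is called first, only, known or untested is meant among the compounds shown, and "the series" means these compounds.

Within the data shown here, in a functional assay on HEK293 cells for agonist activity at Neuronal acetylcholine receptor; alpha4/beta2 (Homo sapiens), read by FLIPR (on this read-out lower numbers stand for an effect already at smaller amounts and higher numbers for an effect only at larger amounts of compound), compound 1 `COc1cc(N2C[C@@H]3CCNC[C@@H]32)cnc1Br` gives 1690 nM, the highest of the three numbers measured so far. Compound 3 `NC(=O)c1cc(N2C[C@@H]3CCNC[C@@H]32)cnc1Br` gives 1490 nM, and compound 2 `COc1cc(N2C[C@H]3CCNC[C@H]32)cnc1Br` gives 200 nM. The step of an 8.5-fold lower number from compound 1 to compound 2 (0.93 log units; beyond the scatter) rests on (the fact that compounds 1 and 2 differ only in the configuration as drawn); the step of a 1.1-fold lower number from compound 1 to compound 3 (0.05 log units; within the scatter) places the carbamoyl-for-methoxy exchange inside the usual scatter. Compound 4 `COc1cncc(N2C[C@@H]3CCNC[C@@H]32)c1` differs from compound 1 by hydrogen in place of bromo on an aromatic carbon. Neither measured step touches the bromo group, so no directly comparable change is on hand, and the mirror-image step and the methoxy exchange do not transfer to it. Compound 4 is therefore expected to show a modest rise in number, a 1.8-fold higher number from compound 1 to compound 4 (0.25 log units; within the scatter). The estimate for compound 4 is 3000 nM, with a range from 1000 nM to 9000 nM.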

Compound 4, half-maximal effective concentration: 7690 nM
Estimate against measurement, compound 4: 2.6-fold (0.41 log units) below; low and high end bracket the measured number.
By their numbers in this assay, from the lowest: compound 2; then compounds 3 and 1 (each within the scatter of the next); then compound 4.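

In this assay, the position next to the ring nitrogen and ortho to the methoxy group is sensitive to the loss of bromo: hydrogen in its place gives a 4.6-fold higher number from compound 1 to compound 4 (0.66 log units; beyond the scatter). Unlike the exchange at the methoxy position, a 1.1-fold lower number from compound 1 to compound 3 (0.05 log units; within the scatter), this change lies beyond the scatter. Nothing on hand accounts for this step.

Open, as far as these compounds go, is whether chloro, methyl or an amine at this position would match bromo or give a lower number than compound 1. Also open, from the compounds shown here alone, is whether removing bromo from compound 2 gives a similar step.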